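Replacing the Amide Phenyl with a 1-Aminoethyl Group

This account rests on a few compounds, and the source may have more. Where it says the series, first, only, none or still open, it means among the compounds named here.

Measured compounds:
compound 1 `Cn1cc(NC(=O)c2ccccc2)c(-c2ccccn2)n1`; in a functional assay on U-87MG ATCC cells (Homo sapiens) for cytotoxicity, read by MTT assay, with a stated time of 24 h (a lower number here means a stronger inhibitor, a higher number a weaker inhibitor), compound 1 gives > 150000 nM.
compound 2 `COc1ccccc1C(=O)Nc1cn(C)nc1-c1ccccn1`; in this assay compound 2 gives 130000 nM.

The value for compound 1 is not a number but a limit of the assay, (the limit of > 150000 nM in this assay, at which 1 of the 2 values shown sits), so compound 1 stands only at that limit and nowhere more exactly. Compound 2 gives a number, and the step of an at least 1.1-fold lower number from compound 1 to compound 2 (0.06 log units; that floor lies within the scatter) lies within the scatter, so the two compounds are not separated.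

Compound 3 `C[C@H](N)C(=O)Nc1cn(C)nc1-c1ccccn1` differs from compound 1 by 1-aminoethyl in place of phenyl on a carbonyl carbon. Among the compounds with values here, no measured step touches the carbonyl carbon; the single step that exists, from compound 1 to compound 2, changes an aromatic carbon and was small. It therefore gives no direct guidance for this change, and the only footing is that both measured compounds sit at the weak end of the assay.

Compound 3 is expected to give 150000 nM, with a range from 40000 nM to 500000 nM. The step of a number no higher from compound 1 to compound 3 (the limit leaves the size open) is expected to stay within the scatter, with a real chance that compound 3 again reports only a limit.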

Compound 3, half-maximal inhibitory concentration: > 150000 nM
Compound 3 ended at the assay's limit; the forecaster's own chance of this, stated with the estimate: 55%; the middle value sits exactly at the limit.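

In this assay compound 3 gives > 150000 nM, which is a limit and not a number. Compound 1 also stands at a limit, so no step can be read from compound 1 to compound 3: the limit of > 150000 nM in this assay, at which 2 of the 3 values shown sit.

The compounds shown leave open whether 1-aminoethyl in place of phenyl on a carbonyl carbon changes the cytotoxicity at all.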